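Halogen variation on the anilinomethyl side of a benzimidazole series

A few compounds are considered here, and "the series" means these few. Any claim that something is new, unique, unknown or untested is made for them only; others in the source may bear on it.

Measured so far:
- compound 1, `Brc1ccc(NCc2nc3ccc(Br)cc3[nH]2)cc1`: 23.5%
- compound 2, `Clc1cccc(NCc2nc3ccc(Br)cc3[nH]2)c1`: 17.6%

Both compounds were tested in a functional assay on the whole organism (strain albino) for inhibition, with Rattus norvegicus as the target, read by paw edema, with a stated time of 120 min, at a dose of 100 mg/kg by the oral route; on this read-out lower numbers stand for less inhibition and higher numbers for more inhibition at the one dose given (going by the name of the read-out). Compound 1 gives 23.5%. Compound 2 gives 17.6%, the lower of the two numbers recorded, with compound 1 the nearest neighbour at a gap that lies within the scatter; on the numbers shown the two cannot be told apart.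

The next compound, compound 3, `Brc1ccc2nc(CNc3ccccc3)[nH]c2c1`, is not yet measured. Relative to compound 2 it carries one change:

hydrogen in place of chloro on an aromatic carbon

Among the compounds with values here, no step between two measured compounds is available, so no measured guide exists for this kind of change. With the two recorded values so close to one another, the expectation for this assay is a step from compound 2 to compound 3 that stays within the scatter, with no clear direction, perhaps leaning slightly lower.

The expected step is a number 2.6 percentage points lower from compound 2 to compound 3 (within the scatter). For compound 3 the estimated result in this assay is 15%, with a likely range from 4% to 28%.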

Compound 3, a percentage reported as inhibition, in the whole organism at one dose (the size of the read-out at that dose, not a potency): 29.4%
The estimate for compound 3 lay 14.4 percentage points below the measured number; the measured number lies above the stated range.
By their numbers in this assay, from the lowest: compounds 2, 1 and 3 (each within the scatter of the next, the first and the last beyond it).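

In this assay, within the data shown here, hydrogen in place of chloro on an aromatic carbon, meta to a large group, gives the first step in this set that lies beyond the scatter, a number 11.8 percentage points higher from compound 2 to compound 3 (beyond the scatter), though it is only a modest one. Hydrogen in place of bromo gives a number 5.9 percentage points higher from compound 1 to compound 3 (within the scatter), which does not separate that pair, so neither single-place comparison shows that a halogen on this ring is needed for the read-out at this one dose. Nothing available bears on why the loss of chloro goes with the higher number.

The compounds shown leave open whether the step belongs to chloro at this place alone or would also appear with fluoro, methoxy, an amine or a carboxylic acid on the same ring. Also open, going by these compounds, is what the bromo on the shared core contributes, since it stays constant across all three compounds, and whether these differences at a single dose would persist at other doses.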